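The source may report more compounds than this note shows. Statements on the series, on what has been measured and on what is new or still open speak of the compounds shown alone.

In a functional assay on HepG2 cells (Homo sapiens) for cytotoxicity, read by MTT assay, with a stated time of 48 h (on this read-out higher numbers stand for weaker inhibition and lower numbers for stronger inhibition), compound 1 `O=C(CSc1nnc(-c2ccncc2)o1)N/N=C/c1ccc(Cl)cc1` gives 15700 nM, compound 2 `COc1ccc(/C=N/NC(=O)CSc2nnc(-c3ccncc3)o2)cc1` gives 15800 nM and compound 3 `O=C(CSc1nnc(-c2ccncc2)o1)N/N=C/c1ccccc1O` gives 3510 nM, the lowest of the three numbers. The steps of a 4.5-fold lower number from compound 1 to compound 3 (0.65 log units; beyond the scatter) and a 4.5-fold lower number from compound 2 to compound 3 (0.65 log units; beyond the scatter) exchange the whole aryl group, while a 1.0-fold higher number from compound 1 to compound 2 (0.00 log units; within the scatter) swaps one aromatic substituent for another. Compound 4 `O=C(CSc1nnc(-c2ccncc2)o1)N/N=C/c1cc(Br)ccc1O` differs from compound 3 by bromo in place of hydrogen on an aromatic carbon. Going by the values given here, no measured step adds a halogen to the hydroxyphenyl, so the nearest guide is the substituent swap from compound 1 to compound 2, which stayed within the scatter. The expected step of a 1.2-fold lower number from compound 3 to compound 4 (0.07 log units; within the scatter) is therefore small, in either direction or none beyond the scatter. For compound 4 the estimate in this assay is 3000 nM, with a range from 1200 nM to 8000 nM.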

Compound 4, half-maximal inhibitory concentration: 6490 nM
Beside the measured number, compound 4's estimate is 2.2-fold (0.34 log units) below it; the measured number falls inside the stated range.
By their numbers in this assay, from the lowest: compounds 3 and 4 (each within the scatter of the next); then compounds 1 and 2 (each within the scatter of the next).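

In this assay, going by these compounds alone, bromo para to the hydroxy group stays within the scatter (a 1.8-fold higher number from compound 3 to compound 4 (0.27 log units; within the scatter)), so this position on the 2-hydroxyphenyl accepts the added atom with no step that can be told from noise. The 5-bromo-2-hydroxyphenyl group still stands apart from the other aryl groups (a 2.4-fold lower number from compound 2 to compound 4 (0.39 log units; beyond the scatter); a 2.4-fold lower number from compound 1 to compound 4 (0.38 log units; beyond the scatter)), so the separation first seen with compound 3 holds for compound 4. No measurement on hand accounts for these steps. From the compounds shown here alone, whether an amine or a carboxylic acid at this position would behave as bromo does remains open. So does whether the 5-bromo aryl group holds its number with methoxy in place of the hydroxy group.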